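The source may hold more compounds than are shown below. What is called first, only, known or untested is meant among the compounds shown, and "the series" means these compounds.

Measured so far:
compound 1 `C/N=C(/NC#N)NCCCn1nc(-c2ccccc2)ccc1=O` – > 100 mg/kg
compound 2 `O=c1ccc(-c2ccccc2)nn1CCCCNC(=S)Nc1ccc(Cl)cc1` – > 100 mg/kg
compound 3 `CC/N=C(/NC#N)NCCCCn1nc(-c2ccccc2)ccc1=O` – 92 mg/kg

In a functional assay on the whole organism (stomach) with Rattus norvegicus as the target (on this read-out higher numbers stand for an effect only at larger amounts of compound and lower numbers for an effect already at smaller amounts), compound 1 gives > 100 mg/kg, which is a limit of the assay and not a number. Compound 2 likewise gives only a limit, > 100 mg/kg. Compound 3 gives a number, 92 mg/kg. Where compound 1 stands is therefore known only as the limit of > 100 mg/kg in this assay, at which 2 of the 3 values shown sit.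

Compound 4 `CC/N=C(/NC#N)NCCCn1nc(-c2ccccc2)ccc1=O` differs from compound 1 by methyl in place of hydrogen on a saturated chain carbon bound to a double-bonded nitrogen. Within the data shown here, no step between measured compounds that differ in one place is available, so the expected step of a number no higher from compound 1 to compound 4 (the limit leaves the size open) is set at none beyond the scatter. Compound 4 is thus estimated at 100 mg/kg, with an expected range from 50 mg/kg to 200 mg/kg, and a fair chance that the assay again reports only a limit.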

Compound 4, dose for half-maximal effect: 78.3 mg/kg
Estimate against measurement, compound 4: 1.3-fold (0.11 log units) above; measured number inside the range.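

In this assay, methyl in place of hydrogen on a saturated chain carbon bound to a double-bonded nitrogen, the methyl to ethyl change, gives an at least 1.2-fold lower number from compound 1 to compound 4 (0.10 log units; that floor lies within the scatter). Among these compounds, this is the first one-place change, and at this place compound 4 gives a number. The step has a floor but no upper size, and compound 1 is held at a limit of the read-out: the limit of > 100 mg/kg in this assay, at which 2 of the 4 values shown sit.

Going by these compounds, whether propyl, a longer chain or a phenyl group at this place moves the number beyond the scatter remains open. So does the effect of a terminal amine or carboxylic acid there.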